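Swapping chloro for hydrogen on the aromatic ring

The source may hold more compounds than are shown below. What is called first, only, known or untested is meant among the compounds shown, and "the series" means these compounds.

Compound 1: `CCN(C(=O)CC(CC(=O)NCCN1CCCC1)c1ccc(Cl)cc1)C1Cc2ccccc2C1`, 55500 nM
Compound 2: `CCNCCNC(=O)CC(CC(=O)N(CC)C1Cc2ccccc2C1)c1ccc(Cl)cc1`, 43800 nM

In a functional assay on MGC-803 cells (Homo sapiens) for inhibition (a lower number here means a stronger inhibitor, a higher number a weaker inhibitor), compound 2 gives 43800 nM and compound 1 gives 55500 nM, so the two cannot be told apart. For the measured compounds named here, the only measured step, a 1.3-fold lower number from compound 1 to compound 2 (0.10 log units; within the scatter), puts ethylamino in place of pyrrolidin-1-yl on a saturated chain carbon.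

Compound 3 `CCNCCNC(=O)CC(CC(=O)N(CC)C1Cc2ccccc2C1)c1ccccc1` departs from compound 2 in one place: hydrogen in place of chloro on an aromatic carbon. The 4-chlorophenyl group thus becomes phenyl. Going by the values given here, the measured step lies elsewhere in the molecule, and no measured pair tests this change, so the data give little guidance. With nothing pointing either way, no step beyond the scatter is expected in this assay, though the uncertainty is wide. The estimated step is a 1.3-fold higher number from compound 2 to compound 3 (0.10 log units; within the scatter). Compound 3 is estimated at 55000 nM, with an expected range of 22000 nM to 130000 nM.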

Compound 3, half-maximal inhibitory concentration: > 100000 nM
Compound 3 was reported as a limit (the forecaster's own chance of this, stated with the estimate: 10%); middle value at least 1.8-fold (0.25 log units) from the limit.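

In this assay, replacing chloro with hydrogen on the aromatic ring gives an at least 2.2-fold higher number from compound 2 to compound 3 (0.35 log units; beyond the scatter). The earlier step, at the amine end of the molecule, stayed within the scatter, so this is the first change shown to move the result beyond it, and it involves a single atom on the ring, para to a large group. Compound 3 gives > 100000 nM, which is a limit of the assay and not a number, so the step has a known minimum but no known full size: the limit of > 100000 nM in this assay, at which 1 of the 3 values shown sits.

As far as these compounds go, it remains open whether chloro is special here, or whether another group at this place, such as fluoro, bromo, methyl or methoxy, would serve as well or better. From the compounds shown here alone, it is also open whether losing the chloro would matter as much with the pyrrolidin-1-yl group of compound 1.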